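Benzyloxycarbonyl for methyl on the methoxyphenyl analogue

The compounds below may be only part of what the source reports. "The series", "measured", "known", "first", "only" and "open" are said of these compounds alone.

In a functional assay on MCF7 cells (Homo sapiens) for antiproliferative activity, read by MTT assay, with a stated time of 48 h (on this read-out higher numbers stand for weaker inhibition and lower numbers for stronger inhibition), compound 1 `Cc1ccc2[nH]c(-c3cn(-c4ccccc4)nc3-c3ccccc3)nc2c1` gives 5940 nM. Compound 2 `O=C(OCc1ccccc1)c1ccc2[nH]c(-c3cn(-c4ccccc4)nc3-c3ccccc3)nc2c1` differs from it by benzyloxycarbonyl in place of methyl on an aromatic carbon, and in this assay compound 2 gives 12600 nM; the step is a 2.1-fold higher number from compound 1 to compound 2 (0.33 log units; beyond the scatter). Compound 3 `COc1ccc(-c2nn(-c3ccccc3)cc2-c2nc3cc(C)ccc3[nH]2)cc1` differs from compound 1 by methoxy in place of hydrogen on an aromatic carbon, and in this assay compound 3 gives 6610 nM; that step is a 1.1-fold higher number from compound 1 to compound 3 (0.05 log units; within the scatter), so the two cores stand within the scatter of one another. Compound 4 `COc1ccc(-c2nn(-c3ccccc3)cc2-c2nc3cc(C(=O)OCc4ccccc4)ccc3[nH]2)cc1` is not yet measured. It differs from compound 3 by benzyloxycarbonyl in place of methyl on an aromatic carbon, the same change as that between compound 1 and compound 2, at a place described in the same words. The expected step is a 2.0-fold higher number from compound 3 to compound 4 (0.31 log units; beyond the scatter), set beside a 2.1-fold higher number from compound 1 to compound 2 (0.33 log units; beyond the scatter). Going by the values given here, this expectation rests on the single earlier pair, compound 1 to compound 2, with a 2.1-fold higher number from compound 1 to compound 2 (0.33 log units; beyond the scatter) as its only guide, and a second occurrence of the change need not repeat the first exactly. For compound 4 in this assay the estimated value is 13500 nM, with an expected range from 7000 nM to 27000 nM.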

Compound 4, half-maximal inhibitory concentration: 7460 nM
For compound 4 the middle estimate is 1.8-fold (0.26 log units) above the measured one, and the stated range covers the measured number.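

In this assay, benzyloxycarbonyl in place of methyl gives a 1.1-fold higher number from compound 3 to compound 4 (0.05 log units; within the scatter), and this step does not differ measurably from its earlier occurrence: the same change on two cores in this assay, a 2.1-fold higher number (0.33 log units; beyond the scatter) from compound 1 to compound 2 and a 1.1-fold higher number (0.05 log units; within the scatter) from compound 3 to compound 4, 1.9-fold (0.27 log units) apart, within the scatter of two such steps. Methoxy in place of hydrogen, read on the two benzyloxycarbonyl compounds, gives a 1.7-fold lower number from compound 2 to compound 4 (0.23 log units; within the scatter), and this step also agrees with its earlier occurrence: the same change on two cores in this assay, a 1.1-fold higher number (0.05 log units; within the scatter) from compound 1 to compound 3 and a 1.7-fold lower number (0.23 log units; within the scatter) from compound 2 to compound 4, 1.9-fold (0.27 log units) apart, within the scatter of two such steps. Carrying either change from one core to the other is therefore consistent with these numbers, but that is only a failure to separate the steps: it does not show that they are equal, and one pair per core cannot fix the size of either change.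

The compounds shown leave open whether a carboxylic acid or a primary amide in place of methyl on that aromatic carbon would fit the same picture. They also leave open whether a hydroxy group or a chlorine in place of methoxy would leave the number as little moved as methoxy does here.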